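The source may hold more compounds than are shown below. What is called first, only, known or untested is meant among the compounds shown, and "the series" means these compounds.

In a functional assay on A549 cells (Homo sapiens) for cytotoxicity (on this read-out lower numbers stand for stronger inhibition and higher numbers for weaker inhibition), compound 2 `O=C1NC(c2ccccc2)CN1S(=O)(=O)c1ccc(Cl)cc1` gives 9470 nM. Compound 1 `O=C1NC(c2ccccc2)CN1S(=O)(=O)c1ccccc1`, which differs from it by hydrogen in place of chloro on an aromatic carbon, gives 145000 nM in this assay; the step of a 15-fold higher number from compound 2 to compound 1 (1.19 log units; beyond the scatter) shows how much this change weakened inhibition. Compound 3 `O=C1NCC(c2ccc(Cl)cc2)N1S(=O)(=O)c1ccc2c(c1)CCC2` carries a different core, and how its core differs from that of compound 2 is not broken down here. For compound 3 this assay reports only a limit, > 265000 nM. Compound 4 `O=C1NCC(c2ccccc2)N1S(=O)(=O)c1ccc2c(c1)CCC2` has not yet been measured; it differs from compound 3 by the same change, (hydrogen in place of chloro on an aromatic carbon). Compound 4 is therefore expected to sit at 600000 nM, with a step that the limit leaves unreadable from compound 3 to compound 4 as the expected step, resting on the weakening seen for compound 1 and on (the limit of > 265000 nM in this assay, at which 1 of the 3 values shown sits), which makes it likely that compound 4 too is reported only as a limit.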

Compound 4, half-maximal inhibitory concentration: 58500 nM
The estimate for compound 4 lay 10-fold (1.01 log units) above the measured number; measured number outside the range, below it.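

Going from chloro to hydrogen on an aromatic carbon did not carry over from one core to the other in this assay, and the two steps run in opposite directions: the same change on two cores in this assay, a 15-fold higher number (1.19 log units; beyond the scatter) from compound 2 to compound 1 and an at least 4.5-fold lower number (0.65 log units; beyond the scatter) from compound 3 to compound 4, at least 69-fold (1.84 log units) apart, beyond the scatter of two such steps. Compound 3 is reported only as a limit, > 265000 nM. The step of an at least 4.5-fold lower number from compound 3 to compound 4 (0.65 log units; beyond the scatter) therefore fixes a direction and a smallest size but not a true size, and two pairs do not show why the outcome depends on the core or how a further core would behave.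

The compounds shown leave open how fluoro, methoxy or an amine in place of chloro would read on either core. They also leave open whether a carboxylic acid there would follow the same split between the two cores.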